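A few compounds are considered here, and "the series" means these few. Any claim that something is new, unique, unknown or untested is made for them only; others in the source may bear on it.

Three compounds share one core and differ only in the fluorine-bearing ring that sits on an oxygen on an aromatic ring. Compound 1 `Cc1nn(C)c(Oc2ccccc2F)c1/C=N\CCCCCCOc1cc2oc(=O)cc(C)c2cc1Cl` carries a 2-fluorophenyl there. In a functional assay on U-87MG ATCC cells for antiproliferative activity against U-87 MG (Homo sapiens), read by MTT assay, with a stated time of 72 h (on this read-out higher numbers stand for weaker inhibition and lower numbers for stronger inhibition), compound 1 gives > 25000 nM, which is a limit of the assay rather than a number. Compound 2 `Cc1nn(C)c(Oc2cccc(F)c2)c1/C=N\CCCCCCOc1cc2oc(=O)cc(C)c2cc1Cl` carries a 3-fluorophenyl instead. In this assay compound 2 gives > 25000 nM, again a limit. Compound 3 `Cc1nn(C)c(Oc2ccc(F)c(F)c2)c1/C=N\CCCCCCOc1cc2oc(=O)cc(C)c2cc1Cl` carries a 3,4-difluorophenyl. In this assay compound 3 gives > 25000 nM, also a limit. Compound 3 thus stands exactly where the other two stand, at the limit of > 25000 nM in this assay, at which 3 of the 3 values shown sit. The steps between these three, a step that the two limits leave unreadable from compound 1 to compound 2, a step that the two limits leave unreadable from compound 1 to compound 3 and a step that the two limits leave unreadable from compound 2 to compound 3, cannot be read, since each joins two limits.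

Compound 4 `Cc1nn(C)c(Oc2cccc(Cl)c2)c1/C=N\CCCCCCOc1cc2oc(=O)cc(C)c2cc1Cl` differs from compound 3 by 3-chlorophenyl in place of 3,4-difluorophenyl on an oxygen on an aromatic ring. Within the data shown here, no measured step gives a readable size for a change of this kind, and all three compounds that vary only in this ring stop at the limit. The step expected in this assay is therefore a step that the limit leaves unreadable from compound 3 to compound 4, with a limit again the most likely outcome. Compound 4 is expected to give 30000 nM in this assay, in a range from 8000 nM to 100000 nM.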

Compound 4, half-maximal inhibitory concentration: 8460 nM
Compound 4: the middle estimate sits 3.5-fold (0.55 log units) above what was measured, within the range that was stated.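

This is the first change on the ring carried by the oxygen that can be read in this assay; the steps among compound 1, compound 2 and compound 3 cannot be read, and the one value that is a number belongs to compound 4, while the others are limits of the assay: the limit of > 25000 nM in this assay, at which 3 of the 4 values shown sit.

The closest comparison exchanges a single halogen, chloro in place of fluoro on an aromatic carbon, and gives an at least 2.9-fold lower number from compound 2 to compound 4 (0.47 log units; beyond the scatter). The other two comparisons point the same way, with an at least 2.9-fold lower number from compound 3 to compound 4 (0.47 log units; beyond the scatter) and an at least 2.9-fold lower number from compound 1 to compound 4 (0.47 log units; beyond the scatter), so among these four compounds the ring on the oxygen can shift antiproliferative activity, and only the 3-chlorophenyl has done so; each of these steps is a minimum, and its true size cannot be told.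

As far as these compounds go, what remains open is whether the gain belongs to chlorine in particular, which a 3-bromophenyl or a 3-methylphenyl on the same oxygen would help to show. From the compounds shown here alone, it is also open whether a 3,4-dichlorophenyl or a 3-trifluoromethylphenyl would carry the number lower still.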